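The source may report more compounds than this note shows. Statements on the series, on what has been measured and on what is new or still open speak of the compounds shown alone.

Going by the values given here, in a functional assay on LoVo cells (Homo sapiens) for inhibition, read by MTT assay, with a stated time of 24 h (a lower number here means a stronger inhibitor, a higher number a weaker inhibitor), two compounds that share one core have numbers so far. Compound 1 `CC1(C)[C@H]2CC[C@]1(C)N(Cc1cn(-c3ccccc3Br)nn1)C(=O)C2`, which carries a 2-bromophenyl on an aromatic nitrogen, gives 60 nM. Compound 2 `CC1(C)[C@H]2CC[C@]1(C)N(Cc1cn(-c3ccc(Br)cc3)nn1)C(=O)C2`, which carries a 4-bromophenyl at that place, gives 60 nM, so it stands level with compound 1 at the digits shown. The next compound, compound 3 `CC1(C)[C@H]2CC[C@]1(C)N(Cc1cn(-c3cccc(Br)c3)nn1)C(=O)C2`, has the same atoms joined differently: 3-bromophenyl in place of 4-bromophenyl on an aromatic nitrogen. Among the compounds with values here, only one measured step bears on this change, the exchange of one bromophenyl for another at the same nitrogen, and it was no change at the digits printed from compound 1 to compound 2 (within the scatter). Within the data shown here, a single step is thin evidence, and the 3-bromophenyl group itself has no measurement yet. Still, the two bromophenyl groups tested so far cannot be told apart in this assay, so no step beyond the scatter is expected here, in either direction. The expected change is no change at the digits printed from compound 2 to compound 3 (within the scatter). For compound 3 the estimated value is 60 nM, with an expected range from 25 nM to 150 nM.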

Compound 3, half-maximal inhibitory concentration: 30 nM
Compound 3: middle estimate off by 2.0-fold (0.30 log units), on the high side; the measured number falls inside the stated range.
By their numbers in this assay, from the lowest: compounds 3, 1 and 2 (each within the scatter of the next).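

With 3-bromophenyl in place of 4-bromophenyl on the aromatic nitrogen, this assay gives a 2.0-fold lower number from compound 2 to compound 3 (0.30 log units; within the scatter) and with 3-bromophenyl in place of 2-bromophenyl it gives a 2.0-fold lower number from compound 1 to compound 3 (0.30 log units; within the scatter) so the third bromophenyl group also falls within the usual scatter of the other two. Going by these compounds alone, the earlier pair covered only two of these groups, whereas all three now stand together, and this assay cannot separate any one of them from the others, so at this resolution the place of the bromine on the phenyl ring shows no measurable effect on the number. No independent measurement is available to explain why the three values lie so close together.

The compounds shown leave open whether the bromine matters at all, since a plain phenyl, or a phenyl carrying a methoxy group, an amine or a carboxylic acid, could give a very different number on this nitrogen. They also say nothing about how much the shared core contributes, as all three compounds carry it unchanged.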